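The source may report more compounds than this note shows. Statements on the series, on what has been measured and on what is new or still open speak of the compounds shown alone.

Measured compounds in an assay on HEK293 cells for displacement of a labelled ligand from Neuronal acetylcholine receptor; alpha4/beta2 (Homo sapiens), read by scintillation counting, with a stated time of 120 min; on this read-out higher numbers stand for weaker inhibition and lower numbers for stronger inhibition:
- compound 1 `FCCCOc1cccc(-c2cn([C@H]3CN4CCC3CC4)nn2)c1` gives 9010 nM
- compound 2 `Fc1cccc(-c2cn([C@H]3CN4CCC3CC4)nn2)c1` gives 5200 nM

Compound 1 stands with the highest of the two numbers shown; the nearest is compound 2, and the step of a 1.7-fold lower number from compound 1 to compound 2 (0.24 log units; within the scatter) is the only measured step in the set, and it is small. That step swaps a fluoro for a 3-fluoropropoxy on an aromatic carbon, which says nothing about stereochemistry.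

Compound 3 `FCCCOc1cccc(-c2cn(C3CN4CCC3CC4)nn2)c1` is the next compound to be measured. Its relation to compound 1 is the two compounds have the same atoms and bonds; at least one stereo element is drawn with a configuration in one of them and without one in the other: 1 of 3 stereo elements differ; a stereocentre at a saturated ring carbon is drawn R in compound 1 and without a configuration in compound 3. The atoms and bonds are identical; only the stereocentre at the saturated ring carbon, drawn R in compound 1, is left without a configuration in compound 3. For the measured compounds named here, no measured step in this set bears on such a change, so the expectation rests on the general case that a sample drawn without a configuration at one centre contains the configuration of compound 1 and at most dilutes it.

The expected step is therefore a 1.3-fold higher number from compound 1 to compound 3 (0.12 log units; within the scatter), a slightly higher number, not beyond the scatter. Compound 3 is estimated at 12000 nM, with a range from 6000 nM to 30000 nM.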

Compound 3, inhibition constant: 3890 nM
Compound 3: the middle estimate sits 3.1-fold (0.49 log units) above what was measured, and the stated range ends above it.
By their numbers in this assay, from the lowest: compounds 3, 2 and 1 (each within the scatter of the next, the first and the last beyond it).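

In this assay, leaving the configuration undrawn at the saturated ring carbon gives a 2.3-fold lower number from compound 1 to compound 3 (0.36 log units; beyond the scatter). For the compounds shown here, this is a modest step, but it is the first in the set to lie beyond the scatter, so this stereocentre is the first place where a change registers on this read-out, and the direction is towards stronger inhibition. The structures offer only one difference to which this step can be attached: the fact that one of compounds 1 and 3 is drawn with a defined configuration and the other without, at the place where they differ

Going by these compounds alone, the make-up of compound 3 remains open, as does the number that the configuration opposite to the one drawn in compound 1 would give on its own with the 3-fluoropropoxy group in place, which would show whether that form accounts for the lower number. Also open, on these data alone, is whether the same stereochemical change gives a step of similar size and direction when the aromatic carbon carries the fluoro of compound 2, or another group such as an amine or a methoxy group.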